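This account rests on a few compounds, and the source may have more. Where it says the series, first, only, none or still open, it means among the compounds named here.

Of the compounds shown here, three built on one shared core have been tested in a functional assay on HCT-116 cells (Homo sapiens) for antiproliferative activity, read by MTT assay, with a stated time of 48 h; on this read-out lower numbers stand for stronger inhibition and higher numbers for weaker inhibition. Compound 1 `Cc1cccc(-n2nncc2CN2C(=O)C3(C(C#N)=C(N)Oc4c3c3nc5ccccc5nc3c3ccccc43)c3ccccc32)c1` gives > 50000 nM in this assay, which is a limit rather than a number. Compound 3 `N#CC1=C(N)Oc2c(c3nc4ccccc4nc3c3ccccc23)C12C(=O)N(Cc1cnnn1-c1cccc(Br)c1)c1ccccc12` likewise returns > 50000 nM, again a limit. Compound 2 `N#CC1=C(N)Oc2c(c3nc4ccccc4nc3c3ccccc23)C12C(=O)N(Cc1cnnn1-c1ccc(F)cc1)c1ccccc12` stands at > 50000 nM, also a limit. Because (the limit of > 50000 nM in this assay, at which 3 of the 3 values shown sit), the steps a step that the two limits leave unreadable from compound 1 to compound 2, a step that the two limits leave unreadable from compound 1 to compound 3 and a step that the two limits leave unreadable from compound 2 to compound 3 cannot be read. Compound 4 `N#CC1=C(N)Oc2c(c3nc4ccccc4nc3c3ccccc23)C12C(=O)N(Cc1cnnn1-c1ccc(Cl)c(Cl)c1)c1ccccc12` arises from compound 2 through the change (3,4-dichlorophenyl in place of 4-fluorophenyl on an aromatic nitrogen). Going by the values given here, none of the measured steps gives a readable size for such a change, so no step beyond the scatter can be foreseen in either direction. Compound 4 is expected to remain near the same limit, the step of a number no higher from compound 2 to compound 4 (the limit leaves the size open) being an estimate only. The estimate for compound 4 is 50000 nM, within 20000 nM to 200000 nM.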

Compound 4, half-maximal inhibitory concentration: > 50000 nM
Compound 4 ended at the assay's limit (the forecaster's own chance of this, stated with the estimate: 85%); the middle value lies on the limit itself.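

The steps linking compound 4 with compound 1, compound 2 and compound 3 cannot be read, since each value is a limit and not a number: the limit of > 50000 nM in this assay, at which 4 of the 4 values shown sit.

The compounds shown leave open whether any aryl group at this place would give a readable value in this assay.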